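Series notes: 1-methyl-1H-indol-6-yl on the shared core

The compounds below may be only part of what the source reports. "The series", "measured", "known", "first", "only" and "open" are said of these compounds alone.

In a functional assay on B16-F0 cells (Mus musculus) for inhibition, read by CCK-8 assay, with a stated time of 48 h (a lower number here means a stronger inhibitor, a higher number a weaker inhibitor), compound 1 `COc1cc(-c2ccnc3cc(-c4ccc(F)cc4)nn23)cc(OC)c1OC` gives 4540 nM, compound 2 `COc1cc(-c2ccnc3cc(-c4ccc(C(F)(F)F)cc4)nn23)cc(OC)c1OC` gives 1770 nM and compound 3 `COc1cc(-c2ccnc3cc(-c4ccc(N(C)C)cc4)nn23)cc(OC)c1OC` gives 702 nM, the lowest of the three numbers. Compound 4 `COc1cc(-c2ccnc3cc(-c4ccc5ccn(C)c5c4)nn23)cc(OC)c1OC` carries 1-methyl-1H-indol-6-yl in place of 4-(dimethylamino)phenyl on an aromatic carbon. Three measured steps at this same place bear on the change: a 2.6-fold lower number from compound 1 to compound 2 (0.41 log units; beyond the scatter), a 2.5-fold lower number from compound 2 to compound 3 (0.40 log units; beyond the scatter) and a 6.5-fold lower number from compound 1 to compound 3 (0.81 log units; beyond the scatter). All are modest but beyond the scatter. None involves a two-ring group, so the direction remains uncertain, with a modest further drop favoured. The largest, a 6.5-fold lower number from compound 1 to compound 3 (0.81 log units; beyond the scatter), sets the expected ceiling on size. The expected result is a 2.0-fold lower number from compound 3 to compound 4 (0.30 log units; within the scatter). For compound 4 the estimated value is 350 nM, within an expected range of 70 nM to 1800 nM.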

Compound 4, half-maximal inhibitory concentration: 657 nM
Estimate against measurement, compound 4: 1.9-fold (0.27 log units) below, within the range that was stated.
By their numbers in this assay, from the lowest: compounds 4 and 3 (each within the scatter of the next); then compound 2; then compound 1.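

In this assay, a two-ring group is accepted at this position: a 1.1-fold lower number from compound 3 to compound 4 (0.03 log units; within the scatter) leaves 1-methyl-1H-indol-6-yl level with 4-(dimethylamino)phenyl, while a 2.7-fold lower number from compound 2 to compound 4 (0.43 log units; beyond the scatter) and a 6.9-fold lower number from compound 1 to compound 4 (0.84 log units; beyond the scatter) keep it clear of the trifluoromethyl and fluoro phenyl groups. The dimethylamino group is therefore not required for a number at this level among these compounds. Nothing available explains why the two groups read alike.

Open, as far as these compounds go, is whether the methyl on the indole nitrogen matters, and whether a morpholine or a carboxylic acid on the phenyl ring would hold this level.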